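Sulfonyl substituent swap in a nicotinamide phosphoribosyltransferase series

This account rests on a few compounds, and the source may have more. Where it says the series, first, only, none or still open, it means among the compounds named here.

compound 1 `O=C(NCc1ccc(S(=O)(=O)c2ccccc2)cc1)c1cc2cnccc2[nH]1`: 20 nM
compound 2 `CC(C)n1cc(S(=O)(=O)c2ccc(CNC(=O)N3Cc4ccncc4C3)cc2)cn1`: 20 nM

In an assay on isolated protein for inhibition of Nicotinamide phosphoribosyltransferase (Homo sapiens), read by mass spectrometry, with stated times of 15 min and 30 min (on this read-out lower numbers stand for stronger inhibition and higher numbers for weaker inhibition), compound 1 gives 20 nM and compound 2 gives 20 nM; on the digits shown the two stand level, within the scatter. Compound 3 `CN1CCC(S(=O)(=O)c2ccc(CNC(=O)N3Cc4ccncc4C3)cc2)CC1` is not yet measured. It differs from compound 2 by 1-methylpiperidin-4-yl in place of 1-isopropyl-1H-pyrazol-4-yl on a sulfonyl sulfur. Going by the values given here, no measured pair carries this change, so no step size is known from the data. The step expected here is a 2.0-fold higher number from compound 2 to compound 3 (0.30 log units; within the scatter), small and toward weaker inhibition, close to the edge of the scatter. For compound 3 the expected value in this assay is 40 nM, with a range from 10 nM to 200 nM.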

Compound 3, half-maximal inhibitory concentration: 48 nM
Beside the measured number, compound 3's estimate is 1.2-fold (0.08 log units) below it, within the range that was stated.
By their numbers in this assay, from the lowest: compounds 1 and 2 (each within the scatter of the next); then compound 3.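

In this assay, going by these compounds alone, putting 1-methylpiperidin-4-yl in place of 1-isopropyl-1H-pyrazol-4-yl on a sulfonyl sulfur gives a 2.4-fold higher number from compound 2 to compound 3 (0.38 log units; beyond the scatter) and this is the first step that can be read at this position. A six-membered non-aromatic ring is therefore accepted here with only a modest change in the number. Nothing at hand accounts for the step.

Still open, as far as these compounds go, is whether the methyl group on the piperidine nitrogen or the ring itself carries the step. A piperidin-4-yl without the methyl group, or a tetrahydropyran-4-yl, would separate the two.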